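Swapping the triazole substituent from benzothiazolone to indole

A few compounds are considered here, and "the series" means these few. Any claim that something is new, unique, unknown or untested is made for them only; others in the source may bear on it.

Among the compounds with values here, compound 2 `O=c1[nH]c2ccc(-n3cc(C[C@H](O)COCCOC[C@@H](O)Cc4ccc(-c5ccccc5)cc4)nn3)cc2s1` carries the only real number here: in a functional assay on HCT-116 cells (Homo sapiens) for inhibition, read by MTT assay, with a stated time of 72 h (a higher number here means a weaker inhibitor of growth, a lower number a stronger inhibitor of growth), compound 2 gives 9200 nM. Compound 1 `O[C@H](COCCOC[C@@H](O)Cc1cn(-c2cncnc2)nn1)Cc1ccc(-c2ccccc2)cc1` reaches only the limit of the assay, > 100000 nM. Within the data shown here, the one measured step, an at least 10-fold lower number from compound 1 to compound 2 (1.03 log units; beyond the scatter), rests on (the limit of > 100000 nM in this assay, at which 1 of the 2 values shown sits). Compound 3 `O[C@H](COCCOC[C@@H](O)Cc1cn(-c2ccc3[nH]ccc3c2)nn1)Cc1ccc(-c2ccccc2)cc1` differs from compound 2 in that (a group of 9 heavy atoms (8 carbon, 1 nitrogen; one five-membered aromatic ring with 1 hetero atom, one six-membered aromatic ring of carbon only) in place of a group of 10 heavy atoms (7 carbon, 1 nitrogen, 1 oxygen, 1 sulfur; one five-membered aromatic ring with 2 hetero atoms, one six-membered aromatic ring of carbon only), on an aromatic nitrogen). This change keeps a bicyclic aromatic group bearing one hydrogen-bond donor on the triazole nitrogen, so a step of modest size, probably toward a somewhat higher number, is expected from compound 2 to compound 3, a 1.6-fold higher number from compound 2 to compound 3 (0.21 log units; within the scatter). Compound 3 is therefore estimated at 15000 nM, between 4000 nM and 60000 nM.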

Compound 3, concentration for 50% growth inhibition: 15500 nM
Beside the measured number, compound 3's estimate is 1.0-fold (0.01 log units) below it, within the range that was stated.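

In this assay, the step of a 1.7-fold higher number from compound 2 to compound 3 (0.23 log units; within the scatter) shows that 1H-indol-5-yl, with neither the sulfur nor the double bond outside aromatic rings, cannot be told apart from the group it replaces on the aromatic nitrogen. It also gives a second comparison with pyrimidin-5-yl: an at least 6.4-fold lower number from compound 1 to compound 3 (0.80 log units; beyond the scatter). Compound 1 stands at a limit of the assay, so this step gives only a bound: the limit of > 100000 nM in this assay, at which 1 of the 3 values shown sits.

Going by these compounds, whether a single phenyl ring would serve as well remains open. So does the effect of an amine or a carboxylic acid on 1H-indol-5-yl.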